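The source may hold more compounds than are shown below. What is called first, only, known or untested is meant among the compounds shown, and "the series" means these compounds.

Measured so far in an ADME assay on HEK293 cells for agonist activity at Toll-like receptor 8 (Homo sapiens), read by a luciferase reporter, with a stated time of 6 h; on this read-out higher numbers stand for an effect only at larger amounts of compound and lower numbers for an effect already at smaller amounts:
compound 1 `CC(C)CCNc1nc(N)nc2ccccc12` gives 2.11 uM
compound 2 `COCCCNc1nc(N)nc2ccccc12` gives 0.01 uM
compound 3 `CCCCNc1nc(N)nc2cc(OC)ccc12` gives 0.3 uM

Compound 3 stands second highest of the three numbers; its nearest neighbour is compound 1 and its furthest is compound 2, both gaps beyond the scatter. For the measured compounds named here, the only step measured, a 210-fold lower number from compound 1 to compound 2 (2.32 log units; beyond the scatter), alters the chain and leaves the ring untouched. Compound 4 `CCCCNc1nc(N)nc2cc(CN(C)C)ccc12` differs from compound 3 on the ring alone: (dimethylamino)methyl in place of methoxy on an aromatic carbon. Going by the values given here, no measured step touches this position, so the chain step offers no guide to size or direction here; the working expectation is no step beyond the scatter, held loosely. Compound 4 is therefore estimated at 0.3 uM, range 0.05 uM to 2 uM, an expected step of no change at the digits printed from compound 3 to compound 4 (within the scatter).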

Compound 4, minimum effective concentration: 0.04 uM
Estimate against measurement, compound 4: 7.5-fold (0.88 log units) above; measured number outside the range, below it.
By their numbers in this assay, from the lowest: compound 2; then compound 4; then compound 3; then compound 1.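

In this assay, this aromatic carbon proves responsive to substitution: (dimethylamino)methyl in place of methoxy gives a 7.5-fold lower number from compound 3 to compound 4 (0.88 log units; beyond the scatter) with the chain left unchanged. The earlier compounds shown here showed a step beyond the scatter only on the chain, whereas this one shows that a change on the ring alone can also lower the number. No measured evidence accounts for this step.

Still open, as far as these compounds go, is whether aminomethyl or a carboxylic acid on this carbon would shift the number in the same direction. Also open, from the compounds shown here alone, is whether (dimethylamino)methyl would lower it with the chain of compound 2 in place.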